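The compounds below may be only part of what the source reports. "The series", "measured", "known", "first", "only" and "open" are said of these compounds alone.

Compound 2 `CCCCCCCCOc1ccc(-c2c(C)[nH]c(=O)n2C2CCCCC2)cc1` gives the highest reading of the three compounds in a functional assay on the whole organism with Rattus norvegicus as the target (a higher number here means that more compound is needed for the effect, a lower number that less compound is needed), at 30 mg/kg. Compound 1 `Cc1[nH]c(=O)n(C)c1-c1ccc(-c2ccccc2)cc1` gives 0.3 mg/kg in this assay, and compound 3 `CCCCCCCCCCOc1ccc(-c2c(C)[nH]c(=O)n2C2CCCCC2)cc1` gives 0.1 mg/kg. Among the measured compounds shown here, the only single step measured, a 300-fold lower number from compound 2 to compound 3 (2.48 log units; beyond the scatter), touches the chain and not the change at hand. Compound 4 `Cc1[nH]c(=O)n(C2CCCCC2)c1-c1ccc(-c2ccccc2)cc1` differs from compound 2 by phenyl in place of octyloxy on an aromatic carbon. For the measured compounds named here, no measured step shows this exchange on its own; compound 1, which carries the phenyl, simply needs far less than compound 2. Compound 4 is therefore expected to need much less than compound 2, a step of a 60-fold lower number from compound 2 to compound 4 (1.78 log units; beyond the scatter) in this assay. Compound 4 is estimated at 0.5 mg/kg, in the range 0.1 mg/kg to 3 mg/kg.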

Compound 4, minimum effective dose: 0.1 mg/kg
Beside the measured number, compound 4's estimate is 5.0-fold (0.70 log units) above it; low and high end bracket the measured number.
By their numbers in this assay, from the lowest: compounds 3 and 4 (each within the scatter of the next); then compound 1; then compound 2.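

Phenyl in place of octyloxy on an aromatic carbon now has a direct reading in this assay as a 300-fold lower number from compound 2 to compound 4 (2.48 log units; beyond the scatter), a large step at this position. Among the compounds shown here, the same compound also gives the first reading at the aromatic nitrogen, where cyclohexyl in place of methyl gives a 3.0-fold lower number from compound 1 to compound 4 (0.48 log units; beyond the scatter), a modest step beyond the scatter. Nothing available bears on the cause of either step. Still open, as far as these compounds go, is whether methoxy or an amine on this aromatic carbon would give a number as low as that of compound 4.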